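Amino for cyano on the aryl ring of the bridged core

The compounds below may be only part of what the source reports. "The series", "measured", "known", "first", "only" and "open" are said of these compounds alone.

Three members of the series have numbers in an assay on HEK293 cells for binding affinity to Neuronal acetylcholine receptor; alpha4/beta2 (Homo sapiens); a higher number here means a weaker inhibitor, a lower number a stronger inhibitor. Compound 1 `N#Cc1ccc2c(c1)C1CNCC2C1` carries a cyano group on its aromatic ring and gives 0.5 nM in this assay. Compound 3 `Cc1nc2cc3c(cc2s1)C1CNCC3C1` extends the core into a fused third aromatic ring and gives 0.12 nM. Compound 2 `Fc1cccc2c1C1CNCC2C1` carries fluorine instead and gives 200 nM. On these three numbers compound 1 stands second highest: compound 3 lies nearest to it and compound 2 lies furthest away, both separations well outside the usual scatter.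

The next compound is compound 4 `Nc1ccc2c(c1)C1CNCC2C1`, which differs from compound 1 in a single place: amino in place of cyano on an aromatic carbon. The change swaps one substituent for another on the shared core of compound 1 and leaves the rest of the molecule untouched.

Within the data shown here, no pair of measured compounds differs in exactly this way, so the step has no direct precedent. The cyano compound 1 is among the strongest binders here, with 0.5 nM in this assay, and the series gives no hint that a donor-bearing amino group will hold that level. An upward move beyond the scatter is expected, though not as far as compound 2 at 200 nM. Compound 4 is therefore estimated at 5 nM in this assay, within a range of 1 nM to 30 nM, which means an expected step of a 10-fold higher number from compound 1 to compound 4 (1.00 log units; beyond the scatter).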

Compound 4, inhibition constant: 100 nM
Beside the measured number, compound 4's estimate is 20-fold (1.30 log units) below it; the whole stated range lies below it.
By their numbers in this assay, from the lowest: compound 3; then compound 1; then compounds 4 and 2 (each within the scatter of the next).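

In this assay, among these compounds, the replacement of cyano by amino gives a 200-fold higher number from compound 1 to compound 4 (2.30 log units; beyond the scatter) on an otherwise unchanged core, the first direct reading of this aromatic carbon, and it shows that the number here depends heavily on which substituent stands at this place. The sub-nanomolar level of compound 1 therefore cannot be taken as a property of the shared core alone, since compound 4 keeps that core and does not retain the level. Cyano and amino differ in heavy atoms, in the triple bond and in hydrogen-bond donors, but no measurement on hand bears on which of these differences accounts for the step.

Among the compounds shown here, the single pair leaves open whether the step reflects the arrival of amino or the departure of cyano, a question that a methoxy group, an acetamide or a carboxylic acid on the same aromatic carbon would help to settle. It also leaves open whether the same exchange would give a step of similar size on the fused third ring of compound 3 or at other carbons of the aromatic ring.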